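Naphthalen-2-yl for 4-nitrophenyl on two cores

The source may report more compounds than this note shows. Statements on the series, on what has been measured and on what is new or still open speak of the compounds shown alone.

Compound 1 `C=C(C)C(=O)c1ccc(OCc2nc(-c3ccc([N+](=O)[O-])cc3)cs2)c(C)c1C` gives 17.2% in an assay on HL-60 cells for inhibition of glutathione S-transferase P (Homo sapiens), read by spectrophotometry, tested at 5 uM; on this read-out lower numbers stand for less inhibition and higher numbers for more inhibition at the one concentration tested (going by the name of the read-out). Compound 2 `C=C(C)C(=O)c1ccc(OCc2nc(-c3ccc4ccccc4c3)cs2)c(C)c1C` carries the change naphthalen-2-yl in place of 4-nitrophenyl on an aromatic carbon and in this assay compound 2 gives 11.3%; the measured step is a number 5.9 percentage points lower from compound 1 to compound 2 (within the scatter). Compound 3 `C=C(CC)C(=O)c1ccc(OCc2nc(-c3ccc([N+](=O)[O-])cc3)cs2)cc1Cl` gives 10.2% in this assay; the difference between the core of compound 3 and the core of compound 1 is not broken down here, so compound 3 and compound 1 are only compared by their two values, which lie within the scatter of each other. Compound 4 `C=C(CC)C(=O)c1ccc(OCc2nc(-c3ccc4ccccc4c3)cs2)cc1Cl` is not yet measured and differs from compound 3 by naphthalen-2-yl in place of 4-nitrophenyl on an aromatic carbon, the same change as that between compound 1 and compound 2, at the same place on the core. The expected step is a number 5.2 percentage points lower from compound 3 to compound 4 (within the scatter), resting on a number 5.9 percentage points lower from compound 1 to compound 2 (within the scatter) on the other core, a step that itself lies within the scatter. A value near that of compound 3 is therefore expected, with a small shift downward. Compound 4 is expected to give 5% in this assay, between -4% and 14%.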

Compound 4, a percentage reported as inhibition, at one concentration (the size of the read-out at that concentration, not a potency): 9.5%
Estimate against measurement, compound 4: 4.5 percentage points below, and the stated range covers the measured number.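

In this assay, naphthalen-2-yl in place of 4-nitrophenyl on the second core reads as a number 0.7 percentage points lower from compound 3 to compound 4 (within the scatter). Set beside the earlier step, the result gives no sign that the change behaves differently on the two cores: the same change on two cores in this assay, a number 5.9 percentage points lower (within the scatter) from compound 1 to compound 2 and a number 0.7 percentage points lower (within the scatter) from compound 3 to compound 4, 5.2 percentage points apart, within the scatter of two such steps. This agrees with the change carrying from one core to the other, but neither step stands out from the scatter, so the two cores share only the absence of a readable effect, and a real effect that transfers between them is not shown.

The compounds shown hold only 4-nitrophenyl and naphthalen-2-yl on this aromatic carbon of the five-membered ring, so a change large enough to test transfer remains open, for example an amine or a carboxylic acid at the same place. Also open, going by these compounds, is how these pairs would compare at other concentrations, as all four readings come from a single concentration and give no potency.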